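Second methoxy on the aryl ring of compound 2

This account rests on a few compounds, and the source may have more. Where it says the series, first, only, none or still open, it means among the compounds named here.

Going by the values given here, compound 2 `COc1ccc(/C=C(\C(=O)c2ccc(Br)cc2)S(=O)(=O)c2ccc(Br)cc2)cc1` gives 25000 nM in a functional assay on DU-145 cells (Homo sapiens) for inhibition, read by trypan blue exclusion, with a stated time of 96 h (a higher number here means a weaker inhibitor of growth, a lower number a stronger inhibitor of growth), the highest of the two numbers so far; compound 1 `O=C(/C(=C\c1ccc(Cl)cc1Cl)S(=O)(=O)c1ccc(Br)cc1)c1ccc(Br)cc1` gives 10000 nM, and the one measured step, a 2.5-fold higher number from compound 1 to compound 2 (0.40 log units; beyond the scatter), concerns a different exchange. Compound 3 `COc1ccc(/C=C(\C(=O)c2ccc(Br)cc2)S(=O)(=O)c2ccc(Br)cc2)c(OC)c1` differs from compound 2 by methoxy in place of hydrogen on an aromatic carbon, read one bond further out as 4-methoxyphenyl to 2,4-dimethoxyphenyl. Among the compounds with values here, no measured step touches the addition of a methoxy group, so nothing beyond the scatter is expected in this assay for compound 3, estimated as no change at the digits printed from compound 2 to compound 3 (within the scatter). Compound 3 is expected at 25000 nM, range 8000 nM to 80000 nM.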

Compound 3, concentration for 50% growth inhibition: 8000 nM
The estimate for compound 3 lay 3.1-fold (0.49 log units) above the measured number; measured number inside the range.
By their numbers in this assay, from the lowest: compounds 3 and 1 (each within the scatter of the next); then compound 2.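

In this assay, the aromatic carbon ortho to a large group responds to substitution: methoxy in place of hydrogen gives a 3.1-fold lower number from compound 2 to compound 3 (0.49 log units; beyond the scatter). The 2,4-dimethoxyphenyl and 2,4-dichlorophenyl groups are not separated, with a 1.3-fold lower number from compound 1 to compound 3 (0.10 log units; within the scatter), so a substituent pair on this ring need not be chloro for this level of growth inhibition. No measurement available here bears on the reason for the shift.

Open, on these data alone, is whether an amine or a longer alkoxy chain on the same carbon would move the number as methoxy does. Also open, as far as these compounds go, is whether the gain from methoxy holds with the bromophenyl groups of the shared core exchanged.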